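The compounds below may be only part of what the source reports. "The series", "measured", "known", "first", "only" and "open" are said of these compounds alone.

Measured compounds:
- compound 1, `COc1cccc(Nc2cc(-c3ccccc3)oc(=O)c2)c1`, gives 0.63 uM in a functional assay on A549 cells (Homo sapiens) for cytotoxicity, read by MTT assay, with a stated time of 72 h; on this read-out higher numbers stand for an effect only at larger amounts of compound and lower numbers for an effect already at smaller amounts
- compound 2, `O=c1cc(NC2CC2)cc(-c2ccccc2)o1`, gives > 30 uM in this assay

Compound 2 stands at the edge of what could be measured: its value in this assay is a limit of the assay, not a number, and (the limit of > 30 uM in this assay, at which 1 of the 2 values shown sits). Compound 1, which carries a methoxyphenyl on the same nitrogen, shows a clear effect at small amounts, so the two measured compounds sit far apart.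

Compound 3, `O=c1cc(Nc2ccccc2)cc(-c2ccccc2)o1`, is not yet measured. It arises from compound 2 by phenyl in place of cyclopropyl on a nitrogen on an aromatic ring. In this way it comes close to compound 1, which differs from compound 3 only by a methoxy on the phenyl.

Compound 2 gives only a limit of the assay, > 30 uM. Compound 1 gives 0.63 uM. Compound 3 is expected to fall between these two and nearer to compound 1. A large step towards an effect at smaller amounts is therefore expected, an at least 15-fold lower number from compound 2 to compound 3 (1.17 log units; beyond the scatter). The estimated value for compound 3 in this assay is 2 uM, with a range from 0.5 uM to 10 uM.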

Compound 3, concentration for half-maximal effect: 0.12 uM
The estimate for compound 3 lay 17-fold (1.22 log units) above the measured number, and the stated range ends above it.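

In this assay, phenyl in place of cyclopropyl on a nitrogen on an aromatic ring gives an at least 250-fold lower number from compound 2 to compound 3 (2.39 log units; beyond the scatter), which shows that the group at this one place can decide whether the shared core has any effect at small amounts. The value of compound 2 is a limit of the assay and not a number, so this step has no exact size: the limit of > 30 uM in this assay, at which 1 of the 3 values shown sits. Hydrogen in place of methoxy on an aromatic carbon gives a 5.3-fold lower number from compound 1 to compound 3 (0.72 log units; beyond the scatter), so the methoxy of compound 1 is not needed for the effect, and the unsubstituted phenyl of compound 3 does better in this comparison.

The compounds shown leave open whether the ring on the nitrogen must be aromatic, since a cyclohexyl group, a six-membered ring that is not aromatic, would help separate ring size from aromatic character. Among these compounds, they also leave open how other groups on the phenyl would behave, such as a fluorine, an amine or a carboxylic acid, since the methoxy of compound 1 is the only such group here and it sits at just one place on that ring.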